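This account rests on a few compounds, and the source may have more. Where it says the series, first, only, none or still open, it means among the compounds named here.

Measured so far in an ADME assay on cells (Hepatocyte, Homo sapiens) for metabolic stability, read by LC-MS, with a stated time of 60 min, tested at 1 uM; on this read-out higher numbers stand for fast clearance and lower numbers for slow clearance:
compound 1, `COc1cc(N(CC2CC2)c2cccc(C(F)(F)F)c2)cnc1C(=O)[C@H]1C[C@@H]1C(=O)O` — 2.3 uL/min
compound 2, `CCN(c1cccc(C(F)(F)F)c1)c1cnc(C(=O)[C@H]2C[C@@H]2C(=O)O)c(OC)c1` — 3.1 uL/min

The numbers for compound 2 and compound 1 lie within the usual scatter of each other, as the step of a 1.3-fold higher number from compound 1 to compound 2 (0.13 log units; within the scatter) shows. Compound 3, `COc1cc(N(Cc2ccc(F)cc2)c2cccc(C(F)(F)F)c2)cnc1C(=O)[C@H]1C[C@@H]1C(=O)O`, is not yet measured; it differs from compound 2 by 4-fluorophenyl in place of methyl on a saturated chain carbon bound to a nitrogen on an aromatic ring. Within the data shown here, the one measured step, a 1.3-fold higher number from compound 1 to compound 2 (0.13 log units; within the scatter), touches the same place but exchanges groups without a ring, whereas here an aromatic ring enters, so it gives only weak guidance. The number for compound 3 is expected to shift by a 1.5-fold higher number from compound 2 to compound 3 (0.16 log units; within the scatter). In this assay compound 3 is estimated at 4.5 uL/min, expected between 1.5 uL/min and 13 uL/min.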

Compound 3, intrinsic clearance in a liver preparation (reported as CLH), per the amount of preparation that the assay uses in the Hepatocyte assay: 4.2 uL/min
Compound 3: the middle estimate sits 1.1-fold (0.03 log units) above what was measured; low and high end bracket the measured number.
By their numbers in the Hepatocyte assay, from the lowest: compounds 1, 2 and 3 (each within the scatter of the next).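

In the Hepatocyte assay, this position takes an aromatic ring with the number staying within the scatter, as the steps show: a 1.4-fold higher number from compound 2 to compound 3 (0.13 log units; within the scatter) and a 1.8-fold higher number from compound 1 to compound 3 (0.26 log units; within the scatter). In a physicochemical assay for lipophilicity, read by LC-MS, in phosphate buffer, measured as octanol-water partition, at pH 7.4 (on this read-out lower numbers stand for lower lipophilicity and higher numbers for higher lipophilicity), compound 2 gives 0.7 and compound 3 gives 1.9. So methyl to 4-fluorophenyl at this place raises lipophilicity clearly while clearance shows no change beyond the scatter: the measured distribution coefficient of compound 2, 0.7, and of compound 3, 1.9, a number 1.20 log units higher (beyond the scatter)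

From the compounds shown here alone, what an amine or a longer chain at this place would do to clearance and to the distribution coefficient stays open.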